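A few compounds are considered here, and "the series" means these few. Any claim that something is new, unique, unknown or untested is made for them only; others in the source may bear on it.

Measured compounds:
compound 1, `CCOC(=O)c1c(-c2c(Cl)c3ccccc3oc2=O)nn(-c2cccc(C)c2)c1C(=O)OCC`: 30000 nM
compound 2, `CCOC(=O)c1c(-c2cc3ccccc3oc2=O)nn(-c2cccc(C)c2)c1C(=O)OCC`: 245000 nM

In a functional assay on HeLa cells (Homo sapiens) for cytotoxicity, read by MTT assay, with a stated time of 48 h (a lower number here means a stronger inhibitor, a higher number a weaker inhibitor), compound 2 gives the highest of the two numbers recorded so far; the nearest is compound 1, and the gap between them is an 8.2-fold higher number from compound 1 to compound 2 (0.91 log units; beyond the scatter), a change of hydrogen in place of chloro on an aromatic carbon. Compound 3, `CCOC(=O)c1c(-c2cc3ccccc3oc2=O)nn(-c2ccc(Cl)cc2)c1C(=O)OCC`, is not yet measured. It differs from compound 2 in one place: 4-chlorophenyl in place of 3-methylphenyl on an aromatic nitrogen. Among the measured compounds shown here, no measured step touches the group on the aromatic nitrogen; the single step recorded, from compound 1 to compound 2, concerns a substituent on a different ring, and so it does not speak to this exchange. With nothing to anchor the direction, the expectation for compound 3 in this assay is a number near that of compound 2, with no step beyond the scatter anticipated, which amounts to an expected step of a 1.2-fold lower number from compound 2 to compound 3 (0.09 log units; within the scatter). Compound 3 is therefore estimated at 200000 nM, with a range from 60000 nM to 600000 nM, and with some chance that the assay reports only a limit.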

Compound 3, half-maximal inhibitory concentration: 87000 nM
Beside the measured number, compound 3's estimate is 2.3-fold (0.36 log units) above it; measured number inside the range.
By their numbers in this assay, from the lowest: compound 1; then compound 3; then compound 2.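

In this assay, the group on the aromatic nitrogen proves able to move the number: 4-chlorophenyl in place of 3-methylphenyl gives a 2.8-fold lower number from compound 2 to compound 3 (0.45 log units; beyond the scatter), something the earlier step, on a different ring, could not show. The two groups are alike in heavy-atom count, in their one six-membered aromatic ring, in having no hydrogen-bond donors or acceptors and in carrying no net charge, yet the exchange alters both the substituent and where it sits on that ring, so this single step cannot separate the two changes. Nothing available accounts for the step, and it stands here as an observation only.

The compounds shown leave open how 3-chlorophenyl or 4-methylphenyl would read on this nitrogen, which would tell the substituent from its place, and how a plain phenyl, or a phenyl carrying an amine or a carboxylic acid, would compare. They also leave open whether 4-chlorophenyl on this nitrogen and the chloro group on the other ring would act independently if combined in one compound.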